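Trimming the Bicyclic Amine Substituent to a Pyrimidine

This account rests on a few compounds, and the source may have more. Where it says the series, first, only, none or still open, it means among the compounds named here.

For the measured compounds named here, compound 2 `Cn1c(=O)c(S(=O)(=O)c2ccc(F)cc2F)cc2cnc(Nc3ccc4cccc(O)c4n3)nc21` is one of three compounds measured in a functional assay on K562 cells (Homo sapiens) for inhibition, read by trypan blue exclusion, with a stated time of 72 h (on this read-out higher numbers stand for weaker inhibition and lower numbers for stronger inhibition), where compound 2 gives 5000 nM, the highest of the three numbers. In this assay compound 1 `Cn1c(=O)c(S(=O)(=O)Cc2ccc(F)cc2F)cc2cnc(Nc3ccc4[nH]ccc4c3)nc21` gives 1000 nM and compound 3 `Cn1ccc2cc(Nc3ncc4cc(S(=O)(=O)c5ccc(Cl)cc5Cl)c(=O)n(C)c4n3)ccc21` gives 750 nM, both beyond the scatter below compound 2, so compound 2 is the weakest inhibitor of the three. Compound 4 `Cn1c(=O)c(S(=O)(=O)c2ccc(F)cc2F)cc2cnc(Nc3ccncn3)nc21` has not been measured. It differs from compound 2 in one place: pyrimidin-4-yl in place of 8-hydroxyquinolin-2-yl on a nitrogen on an aromatic ring. Going by the values given here, no measured pair shows this change, so its effect cannot be read from the data. Compound 4 is expected to lose some potency, a step of a 2.0-fold higher number from compound 2 to compound 4 (0.30 log units; within the scatter). Compound 4 is therefore estimated at 10000 nM, within 2500 nM to 40000 nM.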

Compound 4, half-maximal inhibitory concentration: 30000 nM
The estimate for compound 4 lay 3.0-fold (0.48 log units) below the measured number, within the range that was stated.
By their numbers in this assay, from the lowest: compounds 3 and 1 (each within the scatter of the next); then compound 2; then compound 4.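

In this assay, replacing 8-hydroxyquinolin-2-yl with pyrimidin-4-yl gives a 6.0-fold higher number from compound 2 to compound 4 (0.78 log units; beyond the scatter). For the compounds shown here, this is the first direct reading of this position: inhibition weakens clearly when a two-ring group with a hydrogen-bond donor gives way to a single ring without one. Nothing available explains the loss. Going by these compounds alone, the single change removes a ring and the hydroxyl together, so their separate contributions remain open. A plain quinolin-2-yl group, without the hydroxyl, would separate the second ring from the hydroxyl.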